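The compounds below may be only part of what the source reports. "The series", "measured", "known", "first", "only" and "open" are said of these compounds alone.

Compound 1 `Cn1c(=O)c(=O)n(C2CCCC2)c2nc(N/N=C/c3ccc(O)cc3)ncc21` heads a small set of analogues that differ only in the aryl group on a carbon with a double bond to nitrogen. In a functional assay on PC-3 cells (Homo sapiens) for antiproliferative activity, read by MTT assay (on this read-out lower numbers stand for stronger inhibition and higher numbers for weaker inhibition), compound 1 gives > 100000 nM, which is a limit of the assay rather than a number. Compound 3 `COc1ccc(/C=N/Nc2ncc3c(n2)n(C2CCCC2)c(=O)c(=O)n3C)c(OC)c1` likewise gives > 100000 nM, again a limit. Compound 2 `Cn1c(=O)c(=O)n(C2CCCC2)c2nc(N/N=C/c3ccc(F)c(Cl)c3)ncc21` gives 8550 nM. Of the values shown, two sit at the limit of > 100000 nM in this assay, at which 2 of the 3 values shown sit. Compound 4 `Cn1c(=O)c(=O)n(C2CCCC2)c2nc(N/N=C/c3ccc(OC(F)(F)F)cc3)ncc21` carries trifluoromethyl in place of hydrogen on an oxygen on an aromatic ring; cut one bond further out, hydroxy becomes trifluoromethoxy. The step of an at least 11-fold lower number from compound 1 to compound 2 (1.06 log units; beyond the scatter) shows that exchanging the hydroxyphenyl can bring the value to a measurable number, whereas the step that the two limits leave unreadable from compound 1 to compound 3 cannot be read. A step of an at least 3.3-fold lower number from compound 1 to compound 4 (0.52 log units; beyond the scatter) is expected, with a real chance of only a limit. Compound 4 is estimated at 30000 nM, between 6000 nM and 150000 nM.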

Compound 4, half-maximal inhibitory concentration: 7180 nM
Beside the measured number, compound 4's estimate is 4.2-fold (0.62 log units) above it, and the stated range covers the measured number.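

With the oxygen on the aromatic ring kept and only its hydrogen exchanged, hydroxy to trifluoromethoxy gives an at least 13-fold lower number from compound 1 to compound 4 (1.14 log units; beyond the scatter). A measurable number at this position therefore does not depend on the chlorine and fluorine of compound 2 sitting directly on the ring. The full size of this step stays unknown, as the starting value is only a limit: the limit of > 100000 nM in this assay, at which 2 of the 4 values shown sit.

Still open, from the compounds shown here alone, is whether the oxygen matters at all, or whether the fluorines alone carry the change. A trifluoromethyl, an amine or a carboxylic acid in place of trifluoromethoxy would test this.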